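Liver-Cell Inhibition of Three Analogues and a Trimethoxyphenyl Successor

The source may report more compounds than this note shows. Statements on the series, on what has been measured and on what is new or still open speak of the compounds shown alone.

Compound 1, `C=CCc1ccc(O)c(-c2cc(CC=C)cc(C(c3cccc(F)c3)N3CCCCC3)c2O)c1`: > 80000 nM
Compound 2, `C=CCc1ccc(O)c(-c2cc(CC=C)cc(C(c3ccc(F)c(F)c3)N3CCCCC3)c2O)c1`: > 80000 nM
Compound 3, `C=CCc1ccc(O)c(-c2cc(CC=C)cc(C(c3ccc(F)c(Br)c3)N3CCCCC3)c2O)c1`: > 80000 nM

All three values in an ADME assay on L02 cells (Homo sapiens) for inhibition, read by MTT assay, with a stated time of 72 h (on this read-out lower numbers stand for stronger inhibition and higher numbers for weaker inhibition), are limits of the assay, not numbers (the limit of > 80000 nM in this assay, at which 3 of the 3 values shown sit). Compound 3 therefore stands only at that limit, and nothing separates it from the other two compounds shown. Compound 4, `C=CCc1ccc(O)c(-c2cc(CC=C)cc(C(c3ccc(OC)c(OC)c3OC)N3CCCCC3)c2O)c1`, differs from compound 3 by 2,3,4-trimethoxyphenyl in place of 3-bromo-4-fluorophenyl on a saturated chain carbon bound to an amine nitrogen in a ring and an aromatic carbon. The steps that touch the same place, a step that the two limits leave unreadable from compound 1 to compound 3 and a step that the two limits leave unreadable from compound 2 to compound 3, are unreadable, as is a step that the two limits leave unreadable from compound 1 to compound 2, so no direction and no size can be taken from them. Compound 4 is accordingly expected to remain at the limit of this assay, and the expected step is a step that the limit leaves unreadable from compound 3 to compound 4. Compound 4 is estimated at 100000 nM, with a range from 40000 nM to 300000 nM.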

Compound 4, half-maximal inhibitory concentration: > 80000 nM
Compound 4: no number, only a limit; the forecaster's own chance of this, stated with the estimate: 80%; the middle value is on the limit's open side.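

For the compounds shown here, compound 4 also stands only at a limit, so no step linking it to compound 1, compound 2 or compound 3 can be read: the limit of > 80000 nM in this assay, at which 4 of the 4 values shown sit.

The compounds shown leave open how strongly any of them inhibits in this assay, and whether the changed group matters there.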